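This account rests on a few compounds, and the source may have more. Where it says the series, first, only, none or still open, it means among the compounds named here.

Measured compounds:
- compound 2 `CSc1nc2cc(C)ccn2c(=N)c1S(=O)(=O)c1ccccc1`: in an assay on HeLa cells for displacement of a labelled ligand from 5-hydroxytryptamine receptor 6 (Homo sapiens) (a lower number here means a stronger inhibitor, a higher number a weaker inhibitor), compound 2 gives 41 nM
- compound 1 `CSc1nc2ccccn2/c(=N\C(C)=O)c1S(=O)(=O)c1ccccc1`: in this assay compound 1 gives 83 nM

Compound 2 holds the lower of the two numbers; compound 1 lies higher by a gap that is beyond the scatter. Among the measured compounds shown here, the two compounds differ in more than one place, so no single step between them is counted, and their values show only that compound 2 sits lower in this assay.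

Compound 3 `CCCc1ccn2c(=N)c(S(=O)(=O)c3ccccc3)c(SC)nc2c1` is not yet measured. It differs from compound 2 in one place: ethyl in place of hydrogen on a saturated chain carbon bound to an aromatic carbon; cut one bond further out, the same difference reads methyl to propyl. For the measured compounds named here, no measured pair shows a step of this kind, so there is nothing to lean on beyond the value of compound 2 itself. The expected step is a 1.0-fold lower number from compound 2 to compound 3 (0.01 log units; within the scatter), which is none beyond the scatter, with the direction left open. Compound 3 is therefore expected to give 40 nM, in a range from 15 nM to 110 nM.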

Compound 3, half-maximal inhibitory concentration: 700 nM
Estimate against measurement, compound 3: 18-fold (1.24 log units) below; measured number outside the range, above it.
By their numbers in this assay, from the lowest: compound 2; then compound 1; then compound 3.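

In this assay, ethyl in place of hydrogen on a saturated chain carbon bound to an aromatic carbon, which reads as methyl to propyl when cut one bond further out, gives a 17-fold higher number from compound 2 to compound 3 (1.23 log units; beyond the scatter) and so counts as a large step. Among the compounds shown here, this is the only single-place step, and it shows that the number is sensitive at this place: a change that brings no ring, no hydrogen-bond donor or acceptor and no net charge is enough to move it well beyond the scatter, so propyl is clearly not interchangeable with methyl here. Nothing measured in the compounds shown accounts for the size of this step.

On these data alone, with only methyl and propyl at this place, the shape of the dependence on chain length stays open: an ethyl chain, a branched isopropyl group or a chain ending in an amine or a hydroxyl could fall near either value or outside both. Compound 1 differs from compound 2 in more than one place, so it adds no reading on this position.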